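The compounds below may be only part of what the source reports. "The series", "measured", "known", "first", "only" and "open" are said of these compounds alone.

Three compounds have been measured in a functional assay on HeLa cells (Homo sapiens) for inhibition, with a stated time of 72 h; on this read-out higher numbers stand for an effect only at larger amounts of compound and lower numbers for an effect already at smaller amounts:

Compound 1, `COc1cc(CNCc2ccncc2)ccc1OCc1cccc(F)c1`, gives 4800 nM.
Compound 2, `CCOc1cc(CNCc2ccncc2)ccc1OCc1ccc(Cl)cc1`, gives 2500 nM.
Compound 3, `COc1cc(OCc2cnc(Cl)c(Cl)c2)ccc1CNCc1ccncc1`, gives 400 nM.

Among these three numbers compound 1 stands at the highest. The value of compound 2 lies close to it, within the usual scatter of this assay, so the two cannot be told apart. Within the data shown here, compound 3 sits clearly lower, by a gap beyond the scatter; it is the only one of the three that carries the 5,6-dichloropyridin-3-yl group, though its shared core is substituted in a different arrangement, and no step between it and compound 1 has been worked out.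

The compound still to be measured is compound 4, `COc1cc(CNCc2ccncc2)ccc1OCc1cnc(Cl)c(Cl)c1`. Compared with compound 1 it differs in one place: 5,6-dichloropyridin-3-yl in place of 3-fluorophenyl on a saturated chain carbon bound to an oxygen on an aromatic ring.

Among the measured compounds shown here, no measured pair shows this exact change, so any expectation rests on the numbers at hand. Because compound 3, which carries the same entering group, gives 400 nM, compound 4 is expected to move downward from compound 1 by a step beyond the scatter, a 6.0-fold lower number from compound 1 to compound 4 (0.78 log units; beyond the scatter). The estimate for compound 4 in this assay is 800 nM, with a plausible range from 250 nM to 2500 nM.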

Compound 4, half-maximal effective concentration: 220 nM
Compound 4: middle estimate off by 3.6-fold (0.56 log units), on the high side; the measured number lies below the stated range.
By their numbers in this assay, from the lowest: compounds 4 and 3 (each within the scatter of the next); then compounds 2 and 1 (each within the scatter of the next).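

In this assay, among these compounds, compound 4 gives the first reading of a single change: with the rest of compound 1 left as it is, 5,6-dichloropyridin-3-yl in place of 3-fluorophenyl on a saturated chain carbon bound to an oxygen on an aromatic ring gives a 22-fold lower number from compound 1 to compound 4 (1.34 log units; beyond the scatter), a large step. The earlier compounds shown here could not show this, for no two of them differed in one place only; this position now stands out as one where the group on that carbon can shift the read-out strongly. No measurement shown here speaks to what lies behind the size of this step.

The entering group differs from the one it replaces both in its ring nitrogen and in its two chlorine atoms, and the compounds shown do not tell these apart. An unsubstituted pyridin-3-yl group or a dichlorophenyl group on the same carbon would separate the two, while a (5,6-dichloropyridin-3-yl)methyl group joined through an amine in place of the oxygen would test the link itself.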